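This account rests on a few compounds, and the source may have more. Where it says the series, first, only, none or still open, it means among the compounds named here.

Measured so far:
compound 1 `CC[C@H](N)C(=O)N[C@@H](CC(C)C)B(O)O` – 1500 nM
compound 2 `CC(C)C[C@H](NC(=O)[C@@H](N)C(C)(C)C)B(O)O` – 710 nM

In an ADME assay on FSCLL cells (Homo sapiens) for cytotoxicity, read by MTT assay, with a stated time of 24 h (a lower number here means that less compound is tolerated, a higher number that more compound is tolerated), compound 2 holds the lower of the two numbers, at 710 nM, so it is the less tolerated of the pair. The next compound, compound 3 `CCCC[C@H](N)C(=O)N[C@@H](CC(C)C)B(O)O`, changes one group: butyl in place of tert-butyl on a saturated chain carbon bound to an amine nitrogen and a carbonyl carbon. The two groups hold the same atoms, joined differently.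

Among the compounds with values here, only one measured step bears on this, and it sits at the same place: a 2.1-fold lower number from compound 1 to compound 2 (0.32 log units; beyond the scatter), a modest change seen when tert-butyl replaced ethyl. Within the data shown here, with a single step as a guide and no measured butyl compound, the expectation is cautious. The number may move back up, toward the 1500 nM of compound 1, without clearly passing it. The estimate is a 1.6-fold higher number from compound 2 to compound 3 (0.21 log units; within the scatter), an expected upward step of small size. Compound 3 is expected at 1150 nM, within an estimated range of 450 nM to 3000 nM.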

Compound 3, half-maximal cytotoxic concentration: 950 nM
Beside the measured number, compound 3's estimate is 1.2-fold (0.08 log units) above it; low and high end bracket the measured number.
By their numbers in this assay, from the lowest: compounds 2, 3 and 1 (each within the scatter of the next, the first and the last beyond it).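

In this assay, the step of a 1.3-fold higher number from compound 2 to compound 3 (0.13 log units; within the scatter) stays within the usual scatter, so moving from tert-butyl to butyl, the same four carbons joined differently, gives no difference that these numbers can resolve at this carbon bound to an amine nitrogen and a carbonyl carbon. The comparison with the shorter chain reads the same way: the step of a 1.6-fold lower number from compound 1 to compound 3 (0.20 log units; within the scatter) is also within the scatter, so ethyl and butyl cannot be told apart here, and only a 2.1-fold lower number from compound 1 to compound 2 (0.32 log units; beyond the scatter) lies beyond it, which places compound 3 within the scatter of both neighbours and shows that the one clear gap among these compounds is a small one, not a sharp divide between chain types. Nothing available here explains any of these numbers.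

Larger differences might appear with a group of another kind at this carbon, such as a phenyl ring, a carboxylic acid or an amine at the end of the chain, and these compounds give no guide to that. A chain longer than butyl also remains an open case, as does whether the same small steps would hold if the rest of the shared core were changed.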